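The source may hold more compounds than are shown below. What is called first, only, known or untested is meant among the compounds shown, and "the series" means these compounds.

Measured so far in an ADME assay on Vero cells (Chlorocebus sabaeus) for cytotoxicity, read by MTT assay, with a stated time of 72 h; on this read-out lower numbers stand for higher toxicity in this test and higher numbers for lower toxicity in this test:
- compound 1 `CCOC(=O)c1c(-c2ccc(F)cc2)oc2ccc(OCCCN3C(=O)C(=O)c4cc(F)ccc43)cc12` gives 512000 nM
- compound 2 `CCOC(=O)c1c(-c2ccc(OC)cc2)oc2ccc(OCCCCCCN3C(=O)C(=O)c4cc(F)ccc43)cc12` gives 128000 nM
- compound 3 `CCOC(=O)c1c(-c2ccc(F)cc2)oc2ccc(OCCCN3C(=O)C(=O)c4ccccc43)cc12` gives 256000 nM

Compound 4 `CCOC(=O)c1c(-c2ccc(OC)cc2)oc2ccc(OCCCCCCN3C(=O)C(=O)c4ccccc43)cc12` has not been measured in this assay. The difference between the core of compound 1 and the core of compound 2 is not broken down here. Compound 3 arises from compound 1 by one change, (hydrogen in place of fluoro on an aromatic carbon), and in this assay this gave a 2.0-fold lower number from compound 1 to compound 3 (0.30 log units; within the scatter). The same change, (hydrogen in place of fluoro on an aromatic carbon), leads from compound 2 to compound 4, at the same place on the ring. Because the earlier step of a 2.0-fold lower number from compound 1 to compound 3 (0.30 log units; within the scatter) stayed within the scatter, a step of similar size is expected here, namely a 1.4-fold lower number from compound 2 to compound 4 (0.15 log units; within the scatter). On that basis compound 4 is estimated to give 90000 nM in this assay, expected to fall between 32000 nM and 256000 nM.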

Compound 4, half-maximal cytotoxic concentration: 256000 nM
For compound 4 the middle estimate is 2.8-fold (0.45 log units) below the measured one, within the range that was stated.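

In this assay, putting hydrogen in place of fluoro on the aromatic carbon gives a 2.0-fold higher number from compound 2 to compound 4 (0.30 log units; within the scatter). Set beside the earlier step, the same change moves the number in opposite directions on the two cores: the same change on two cores in this assay, a 2.0-fold lower number (0.30 log units; within the scatter) from compound 1 to compound 3 and a 2.0-fold higher number (0.30 log units; within the scatter) from compound 2 to compound 4, 4.0-fold (0.60 log units) apart, beyond the scatter of two such steps. The step therefore did not carry over as a fixed amount from one core to the other, but each step alone lies within the scatter, so this does not show that the change truly raises or lowers the number on either core, or which difference between the cores accounts for the gap.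

The compounds shown leave open how a different group at this aromatic carbon, such as chloro, nitrile or an amine, would behave. They also leave open whether the hexyl-length chain or the methoxy group matters more, since the two cores differ in both.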